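Substituting the phenyl ring on a thiazole-linked carboxylic acid

The source may hold more compounds than are shown below. What is called first, only, known or untested is meant among the compounds shown, and "the series" means these compounds.

Measured so far:
compound 1, `Cc1nc(-c2ccccc2)sc1COc1ccc2c(c1)OCC2CC(=O)O`, 54.8%
compound 2, `Cc1nc(-c2cccc(C(F)(F)F)c2)sc1COc1ccc2c(c1)OCC2CC(=O)O`, 35.7%

The two measured compounds share a core and differ only on the phenyl ring attached to the five-membered aromatic ring with one nitrogen and one sulfur. In a functional assay on CHO cells for agonist activity at Free fatty acid receptor 1 (Homo sapiens), read by FLIPR and calcium flux, tested at 100 nM (on this read-out higher numbers stand for a stronger effect at the one concentration tested and lower numbers for a weaker effect), compound 1 gives 54.8%, the higher of the two numbers; compound 2 in this assay gives 35.7%. Going by the values given here, the step of a number 19.1 percentage points lower from compound 1 to compound 2 (beyond the scatter) is the only measured change on that ring, and it lowered the read-out.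

Compound 3, `COc1cc(OC)cc(-c2nc(C)c(COc3ccc4c(c3)OCC4CC(=O)O)s2)c1`, has not yet been measured. It differs from compound 1 in one place: 3,5-dimethoxyphenyl in place of phenyl on an aromatic carbon.

Among the compounds with values here, the only step that bears on this change is the one from compound 1 to compound 2, which put a single trifluoromethyl on the ring and cost a modest amount. The new change instead adds two methoxy groups, so the direction of that step is at best a loose guide. A decrease of similar or smaller size is expected, with wide uncertainty.

Compound 3 is therefore estimated to give 45% in this assay, within a range from 25% to 65%. This estimate means an expected step of a number 9.8 percentage points lower from compound 1 to compound 3 (within the scatter).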

Compound 3, a percentage reported as activity, at one concentration (the size of the read-out at that concentration, not a potency): 17.5%
Compound 3: the middle estimate sits 27.5 percentage points above what was measured, outside the stated range (below it).
By their numbers in this assay, from the lowest: compound 3; then compound 2; then compound 1.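

In this assay, putting 3,5-dimethoxyphenyl in place of phenyl gave a number 37.3 percentage points lower from compound 1 to compound 3 (beyond the scatter), and putting it in place of 3-(trifluoromethyl)phenyl gave a number 18.2 percentage points lower from compound 2 to compound 3 (beyond the scatter). The ring attached to the shared core therefore does not respond to substitution by a single fixed amount: the two methoxy groups lowered the read-out further than the one trifluoromethyl group, and among these three compounds the unsubstituted phenyl of compound 1 stays highest, with no compound going against that order. No measurement at hand explains why the read-out fell with either group, so the result records the size of the change but not its origin.

The compounds shown leave open whether a single methoxy group on the phenyl ring would already lower the read-out or whether the full loss requires both methoxy groups, and whether a fluorine atom, a methyl group or an amine would fare any better than phenyl itself. Each compound also has a read-out at only one concentration, so these numbers cannot say whether potency, maximal effect or both changed across the series.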